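Two Chlorines Added to a Benzyl Group: An Expectation

This account rests on a few compounds, and the source may have more. Where it says the series, first, only, none or still open, it means among the compounds named here.

Of the compounds shown here, two have so far been measured in an assay with adenosine receptor A1 (Rattus norvegicus) as the target; a lower number here means that less compound is needed, a higher number that more compound is needed for the effect. Compound 1 `Nc1sc2c(c1C(=O)c1cccc(Cl)c1)CCCC2` gives 10500 nM. Compound 2 `Nc1sc2c(c1C(=O)c1ccc(Cl)cc1)CCN(Cc1ccccc1)C2` gives 11300 nM, which is the higher of the two numbers, though its gap to compound 1 lies within the scatter, so the two cannot be placed in any order. Compound 3 `Nc1sc2c(c1C(=O)c1ccc(Cl)cc1)CCN(Cc1ccc(Cl)c(Cl)c1)C2` has not yet been measured. It differs from compound 2 in one place: 3,4-dichlorophenyl in place of phenyl on a saturated chain carbon bound to an amine nitrogen in a ring. Within the data shown here, no measured pair shows what such a change does in this assay, so any expectation rests only on the two values already seen, both of which sit at high concentrations. The step from compound 2 to compound 3 is expected to be a 1.4-fold lower number from compound 2 to compound 3 (0.15 log units; within the scatter), a shift that may not rise clearly beyond the scatter. For compound 3 the estimated value in this assay is 8000 nM, within a range from 2000 nM to 30000 nM.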

Compound 3, half-maximal effective concentration: 32000 nM
Estimate against measurement, compound 3: 4.0-fold (0.60 log units) below, outside the stated range (above it).
By their numbers in this assay, from the lowest: compounds 1 and 2 (each within the scatter of the next); then compound 3.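

On a saturated chain carbon bound to an amine nitrogen in a ring, 3,4-dichlorophenyl in place of phenyl gives a 2.8-fold higher number from compound 2 to compound 3 (0.45 log units; beyond the scatter) in this assay, a modest step but one beyond the scatter. Among these compounds, the earlier values could not show this: they gave no measured pair, whereas this step shows that the number at this position responds to the change from benzyl to 3,4-dichlorobenzyl, and that it moves upward, so that more compound is needed. No measurement at hand accounts for the shift.

The compounds shown leave open whether a single chlorine on the phenyl would give part of this step, and whether a methoxy group or an amine there would move the number the same way. They also leave open whether the step keeps its size when the rest of the shared core changes.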